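The source may report more compounds than this note shows. Statements on the series, on what has been measured and on what is new or still open speak of the compounds shown alone.

Measured in a physicochemical assay for solubility, in phosphate buffer, at pH 7.4; a higher number here means a more soluble compound, a lower number a less soluble compound:
- compound 1 `OCC1CCN(c2nccnc2OC2CN(c3ccc4ccccc4n3)C2)C1`: 167000 nM
- compound 2 `c1ccc2nc(N3CC(Oc4nccnc4-c4ccncc4)C3)ccc2c1`: 56000 nM
- compound 3 `c1ccc2nc(N3CC(Oc4nccnc4-c4ccc5scnc5c4)C3)ccc2c1`: < 1000 nM

The entry for compound 3 is a limit of the assay and not a number, so compound 3 has only a ceiling to its name, (the limit of < 1000 nM in this assay, at which 1 of the 3 values shown sits).

Compound 4 `CS(=O)(=O)N1CCC(c2nccnc2OC2CN(c3ccc4ccccc4n3)C2)CC1` has not yet been measured. It carries 1-(methylsulfonyl)piperidin-4-yl in place of 1,3-benzothiazol-5-yl on an aromatic carbon, next to the ring nitrogen: 1-(methylsulfonyl)piperidin-4-yl in place of 1,3-benzothiazol-5-yl on an aromatic carbon.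

Among the compounds with values here, two measured steps bear directly on this change, since both bring in the group that now leaves. Setting 1,3-benzothiazol-5-yl in place of pyridin-4-yl gives an at least 56-fold lower number from compound 2 to compound 3 (1.74 log units; beyond the scatter), and setting it in place of 3-(hydroxymethyl)pyrrolidin-1-yl gives an at least 160-fold lower number from compound 1 to compound 3 (2.22 log units; beyond the scatter). Both are large. The exchange between the other two groups at this place is modest by comparison, at a 3.0-fold lower number from compound 1 to compound 2 (0.47 log units; beyond the scatter).

Given an at least 56-fold lower number from compound 2 to compound 3 (1.74 log units; beyond the scatter) and an at least 160-fold lower number from compound 1 to compound 3 (2.22 log units; beyond the scatter), removing 1,3-benzothiazol-5-yl is expected to reverse much of that loss, although the entering group itself has never been tested here. The step estimated in this assay is an at least 15-fold higher number from compound 3 to compound 4 (1.17 log units; beyond the scatter), a large one towards a higher number.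

For compound 4 the expected value is 15000 nM, with an estimated range from 3000 nM to 60000 nM.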

Compound 4, solubility: 181000 nM
Compound 4: the middle estimate sits 12-fold (1.08 log units) below what was measured, and the stated range ends below it.
By their numbers in this assay, from the lowest: compound 2; then compounds 1 and 4 (each within the scatter of the next). At a limit, below all of these: compound 3.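

In this assay, the single non-aromatic ring of 1-(methylsulfonyl)piperidin-4-yl on this aromatic carbon gives an at least 180-fold higher number from compound 3 to compound 4 (2.25 log units; beyond the scatter), showing that the low end set by 1,3-benzothiazol-5-yl does not extend to every large group at this place. The new group also gives a 3.2-fold higher number from compound 2 to compound 4 (0.51 log units; beyond the scatter) and a 1.1-fold higher number from compound 1 to compound 4 (0.03 log units; within the scatter), so among the compounds shown, the top of the range at this position is reached both with and without a hydroxymethyl group. The entry for compound 3 is a limit and not a number, so the step from it has a lower bound only: the limit of < 1000 nM in this assay, at which 1 of the 4 values shown sits.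

The compounds shown leave open which part of 1,3-benzothiazol-5-yl goes with the low entry, since a plain phenyl or a lone thiazole at this place would separate the fused pair of rings from the sulfur and nitrogen they carry. They also leave open what the methylsulfonyl contributes, a question that an acetyl on the piperidine nitrogen, or a bare piperidin-4-yl, would address.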